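The source may hold more compounds than are shown below. What is called first, only, known or untested is meant among the compounds shown, and "the series" means these compounds.

Going by the values given here, in a functional assay on SK-BR-3 cells (Homo sapiens) for cytotoxicity, read by sulforhodamine B assay, with a stated time of 72 h (on this read-out higher numbers stand for an effect only at larger amounts of compound and lower numbers for an effect already at smaller amounts), compound 1 `Cc1cccc(-c2cc3occ(C)c3c(=O)o2)c1` gives 1.5 uM and compound 2 `CCOc1cccc(-c2cc3occ(C)c3c(=O)o2)c1` gives 0.67 uM, the lower of the two numbers so far. Compound 3 `Cc1coc2cc(-c3cccc(O)c3)oc(=O)c12` has hydrogen in place of ethyl on an oxygen on an aromatic ring. Among the compounds with values here, only one measured step bears on this change, a 2.2-fold lower number from compound 1 to compound 2 (0.35 log units; beyond the scatter), with ethoxy in place of methyl on an aromatic carbon, and it was modest. A modest rise in the number is therefore expected, an estimated 2.2-fold higher number from compound 2 to compound 3 (0.35 log units; beyond the scatter). The expected value for compound 3 is 1.5 uM, with an estimated range from 0.5 uM to 5 uM.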

Compound 3, concentration for half-maximal effect: 1.61 uM
The estimate for compound 3 lay 1.1-fold (0.03 log units) below the measured number; low and high end bracket the measured number.
By their numbers in this assay, from the lowest: compound 2; then compounds 1 and 3 (each within the scatter of the next).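

Going from ethoxy to hydroxy gives a 2.4-fold higher number from compound 2 to compound 3 (0.38 log units; beyond the scatter) and so shows that the ethyl on this oxygen matters, not the oxygen alone. Hydroxy and methyl cannot be told apart here, with a 1.1-fold higher number from compound 1 to compound 3 (0.03 log units; within the scatter) and so, among these three compounds, only the ethoxy of compound 2 stands apart. No outside measurement is available to explain this difference. As far as these compounds go, whether a longer chain, such as propyl or butyl, on this oxygen would lower the number further remains open, as does the effect of an amine or a carboxylic acid in this place.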